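A few compounds are considered here, and "the series" means these few. Any claim that something is new, unique, unknown or untested is made for them only; others in the source may bear on it.

Measured so far in an ADME assay on MT4 cells (Homo sapiens) for cytotoxicity, read by MTT assay; on this read-out higher numbers stand for lower toxicity in this test and lower numbers for higher toxicity in this test:
- compound 1 `Cc1c(Cc2c(F)cccc2F)nc(SCc2ccccc2)[nH]c1=O`: > 70000 nM (a limit)
- compound 2 `COc1ccc(CCSc2nc(Cc3c(Cl)cccc3Cl)c(C)c(=O)[nH]2)cc1`: > 57000 nM (a limit)

Neither entry is a number. Compound 2 stands at > 57000 nM, which is a limit of the assay. Compound 1 stands at > 70000 nM, which is also a limit. The two compounds therefore give no measured value to anchor the series, and they cannot be placed in order.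

The next compound is compound 3 `Cc1c(Cc2c(Cl)cccc2Cl)nc(SCC(=O)c2ccccc2)[nH]c1=O`. It has benzoyl in place of 4-methoxybenzyl on a saturated chain carbon bound to a sulfur.

For the measured compounds named here, no step between measured compounds is available, so the series gives no direct measure of what such a change does in this assay. No step beyond the scatter is expected, in either direction. This expectation rests only on compound 2 at > 57000 nM, a limit. The expected step of an at least 1.1-fold lower number from compound 2 to compound 3 (0.05 log units; that floor lies within the scatter) is small. Compound 3 is more likely than not to be reported as a limit as well. For compound 3 the estimated value is 50000 nM, with an expected range from 15000 nM to 100000 nM.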

Compound 3, half-maximal cytotoxic concentration: > 60000 nM
Compound 3: only a limit was reported (the forecaster's own chance of this, stated with the estimate: 65%); middle value at least 1.2-fold (0.07 log units) from the limit.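

In this assay, compound 2 and compound 3 are both reported only as limits, so no step can be read between them. The compounds shown leave open where their actual values lie and whether benzoyl in place of 4-methoxybenzyl on a saturated chain carbon bound to a sulfur changes this read-out at all.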